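Swapping the Side Chain on a Shared Core

This account rests on a few compounds, and the source may have more. Where it says the series, first, only, none or still open, it means among the compounds named here.

Three compounds were measured in a functional assay for inhibition, with Homo sapiens as the target; a higher number here means weaker binding, a lower number tighter binding:
compound 1, `N#Cc1ccccc1C1OCC(C/C=C\CCC(=O)O)C(c2cccnc2)O1`, gives 245 nM;
compound 2, `O=C(O)CC/C=C\CC1COC(c2ccsc2)OC1c1cccnc1`, gives 1580 nM;
compound 3, `COc1ccc(OC(C)(C)C2OCC(C/C=C\CCC(=O)O)C(c3cccnc3)O2)cc1`, gives 302 nM.

Compound 3 stands second highest of the three numbers. Its nearest neighbour is compound 1, whose number is only slightly lower and lies within the scatter, so the two cannot be ranked; compound 2 sits furthest away with a clearly higher number.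

Compound 4, `CC(C)(Cc1ccc(F)cc1)C1OCC(C/C=C\CCC(=O)O)C(c2cccnc2)O1`, differs from compound 3 in one place: 4-fluorobenzyl in place of 4-methoxyphenoxy on a saturated chain carbon bound to two saturated chain carbons and a saturated ring carbon. For the measured compounds named here, the only measured step, a 6.4-fold higher number from compound 1 to compound 2 (0.81 log units; beyond the scatter), changes a group on a saturated ring carbon, not on the saturated chain carbon touched here, so it does not bear directly on this change. Going by the values given here, with no step at the same place to draw on, the expectation is no move beyond the scatter, leaning neither way. Compound 4 is therefore expected to give about 300 nM, within 100 nM to 1000 nM, which means an expected step of a 1.0-fold lower number from compound 3 to compound 4 (0.00 log units; within the scatter).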

Compound 4, dissociation constant: 89.1 nM
For compound 4 the middle estimate is 3.4-fold (0.53 log units) above the measured one; measured number outside the range, below it.
By their numbers in this assay, from the lowest: compound 4; then compounds 1 and 3 (each within the scatter of the next); then compound 2.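

Changing the group at this position does move the result: in this assay, 4-fluorobenzyl in place of 4-methoxyphenoxy gives a 3.4-fold lower number from compound 3 to compound 4 (0.53 log units; beyond the scatter). For the compounds shown here, the earlier step concerned a saturated ring carbon, so this is the first sign that the saturated chain carbon also matters, and that a group here can give a lower number while keeping one six-membered aromatic ring of carbon only. The leaving group counts 2 hydrogen-bond acceptors and the entering group 0, but no measurement here explains the shift.

This swap changes both the atom joining the ring to the chain and the group on the ring, so the compounds shown do not tell which of the two matters. A 4-fluorophenoxy or 4-methoxybenzyl group at this position would pull those two changes apart.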